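The source may report more compounds than this note shows. Statements on the series, on what has been measured and on what is new or still open speak of the compounds shown alone.

Measured compounds, each with its result in an assay on HEK293 cells for positive allosteric modulation of metabotropic glutamate receptor 5 (Homo sapiens), read by FLIPR, with a stated time of 1 h; on this read-out higher numbers stand for an effect only at larger amounts of compound and lower numbers for an effect already at smaller amounts:

Compound 1, `Cc1cccc(C#Cc2nc3c(s2)C(=O)NCC3)c1`, gives > 10000 nM.
Compound 2, `Fc1cccc(C#Cc2nc3c(s2)CN(C2CCOC2)CC3)c1`, gives > 10000 nM.
Compound 3, `C(#Cc1nc2c(s1)CN(C1CCCCC1)CC2)c1ccccc1`, gives > 10000 nM.

Each of these three results is a limit of the assay and not a number: the compound showed no effect up to the highest amount tested. Compound 3 therefore does not stand anywhere on a scale of numbers; it sits at the limit of > 10000 nM in this assay, at which 3 of the 3 values shown sit, where every value shown so far also sits, so no ordering among the three is possible.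

The next compound, compound 4, `O=C(C1CCCCC1)N1CCc2nc(C#Cc3ccccc3)sc2C1`, differs from compound 3 in one place: cyclohexylcarbonyl in place of cyclohexyl on an amine nitrogen in a ring. The amine nitrogen in the ring thus carries an amide group instead of a plain ring substituent.

Within the data shown here, no step between two measured compounds has been characterised, so there is no measured change to lean on. Among the compounds at hand, a carbonyl group already appears in compound 1 without bringing any effect within the range tested. The expectation is therefore that the step of an at least 1.2-fold lower number from compound 3 to compound 4 (0.09 log units; that floor lies within the scatter) stays within the usual scatter, with a fair chance that only a limit is reported again. Compound 4 is estimated at 8000 nM, within the range 2000 nM to 30000 nM.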

Compound 4, half-maximal effective concentration: 167 nM
Compound 4: the middle estimate sits 48-fold (1.68 log units) above what was measured, outside the stated range (below it).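

In this assay, the amine nitrogen in the ring proves to be a place where the attached group can separate no measurable effect from a clear one: putting cyclohexylcarbonyl in place of cyclohexyl gives an at least 59-fold lower number from compound 3 to compound 4 (1.77 log units; beyond the scatter). The six-membered carbon ring is present on both sides of this step, so what changes is the carbonyl, which brings one hydrogen-bond acceptor into the structure and turns the amine nitrogen into an amide nitrogen. The step has only a lower bound and not an exact size, since it starts from compound 3, whose result is a limit of the assay and not a number: the limit of > 10000 nM in this assay, at which 3 of the 4 values shown sit.

The compounds shown leave open whether the carbonyl itself is what counts, or whether another group on the same nitrogen, such as a sulfonyl, a urea or a carbamate, would serve as well. They also leave open how much the cyclohexyl part contributes once the carbonyl is in place, which a phenyl ring or a short alkyl chain in its position would help to show.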